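The source may hold more compounds than are shown below. What is called first, only, known or untested is meant among the compounds shown, and "the series" means these compounds.

Compound 1, `Fc1ccc(F)c(-c2nc3ncccc3o2)c1`, gives 18% in a functional assay on the whole organism for inhibition, with Rattus norvegicus as the target, at a dose of 30 mg/kg; on this read-out lower numbers stand for less inhibition and higher numbers for more inhibition at the one dose given (going by the name of the read-out).
Compound 2, `COc1ccc(Br)c(-c2nc3ncccc3o2)c1`, gives 8% in this assay.
Compound 3, `Brc1cccc(-c2nc3ncccc3o2)c1`, gives 23% in this assay.

All three share one core and differ only in the groups carried on the outer six-membered aromatic ring. The number for compound 3 is the largest of the three, but the gap between compound 3 and compound 1 lies within the usual scatter of repeated measurements, so no order between those two can be read from it. Only the gap between compound 3 and compound 2 lies beyond the scatter.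

Compound 4, `COc1cccc(-c2nc3ncccc3o2)c1`, has not yet been measured in this assay. It arises from compound 3 through the change (methoxy in place of bromo on an aromatic carbon), that is, methoxy in place of bromo on an aromatic carbon. Among the compounds with values here, no measured pair differing in exactly this way is available, so the size of the step can only be guessed from the three numbers above.

Because compound 2, which also carries a methoxy group, gives 8%, a step downward is expected, from compound 3 to compound 4 of about a number 11 percentage points lower from compound 3 to compound 4 (beyond the scatter). Compound 4 is thus estimated to give 12%, within a range from 0% to 30%.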

Compound 4, a percentage reported as inhibition, in the whole organism at one dose (the size of the read-out at that dose, not a potency): 14%
Compound 4: middle estimate off by 2 percentage points, on the low side, within the range that was stated.
By their numbers in this assay, from the lowest: compounds 2, 4, 1 and 3 (each within the scatter of the next, the first and the last beyond it).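

Placing methoxy where bromo stood on an aromatic carbon, with the rest of the molecule unchanged, gives the first direct reading of this change in this assay: the result is a number 9 percentage points lower from compound 3 to compound 4 (within the scatter), so the two groups cannot be ranked at this position. Within the data shown here, compound 4 also gives the first comparison that isolates the bromo of compound 2, and putting hydrogen in place of that bromo gives a number 6 percentage points higher from compound 2 to compound 4 (within the scatter), so this change likewise shows no effect that can be told apart from the ordinary spread of repeated measurements. No measurement at hand offers an explanation for these numbers.

Going by these compounds, whether a different kind of group at the position of the methoxy, such as an amine, a carboxylic acid or a longer chain, would produce a step beyond the scatter remains open. Also open, on these data alone, is what the shared core gives with only hydrogen on the outer ring, a baseline against which both bromo and methoxy could be judged.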